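From pyridin-4-yl to 3-fluorophenyl in a cell assay

The compounds below may be only part of what the source reports. "The series", "measured", "known", "first", "only" and "open" are said of these compounds alone.

Compound 1 (`COc1ccc(S(=O)(=O)N2CCc3cccc(-c4ccc(N(C)C)cc4)c32)cc1`) gives 556 nM
Compound 2 (`COc1ccc(S(=O)(=O)N2CCc3cccc(-c4ccncc4)c32)cc1`) gives 101 nM

For the measured compounds named here, compound 2 holds the lower of the two numbers so far in a functional assay on NCI-H460 cells (Homo sapiens) for inhibition, with a stated time of 72 h (on this read-out lower numbers stand for stronger inhibition and higher numbers for weaker inhibition), and is the starting point here. Compound 3 (`COc1ccc(S(=O)(=O)N2CCc3cccc(-c4cccc(F)c4)c32)cc1`) carries 3-fluorophenyl in place of pyridin-4-yl on an aromatic carbon. Going by the values given here, one measured step bears on this change, the swap of 4-(dimethylamino)phenyl for pyridin-4-yl (a 5.5-fold lower number from compound 1 to compound 2 (0.74 log units; beyond the scatter)), which was modest. Compound 3, like compound 1, has a substituted phenyl there, so on that step alone a move towards higher numbers is expected. The expected change is somewhat smaller (a 2.8-fold higher number from compound 2 to compound 3 (0.44 log units; beyond the scatter)). The estimate for compound 3 is 280 nM with an expected range from 80 nM to 900 nM in this read-out.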

Compound 3, half-maximal inhibitory concentration: 167 nM
Compound 3: the middle estimate sits 1.7-fold (0.22 log units) above what was measured, within the range that was stated.
By their numbers in this assay, from the lowest: compounds 2 and 3 (each within the scatter of the next); then compound 1.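

In this assay, a ring of carbon only can stand at this position without leaving the scatter around pyridin-4-yl, with a 1.7-fold higher number from compound 2 to compound 3 (0.22 log units; within the scatter). A substituted phenyl therefore does not by itself give the higher number of compound 1, as a 3.3-fold lower number from compound 1 to compound 3 (0.52 log units; beyond the scatter) shows. No evidence is at hand to explain either step.

The compounds shown leave open whether the gap between 3-fluorophenyl and 4-(dimethylamino)phenyl follows from the substituent or from where it sits. They also leave open how an amine or a carboxylic acid on that phenyl would read.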